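This account rests on a few compounds, and the source may have more. Where it says the series, first, only, none or still open, it means among the compounds named here.

Working notes on the series.

Compound 1 `CC(O)(CSc1cccc(C(F)(F)F)c1)C(=O)Nc1cccc(S(F)(F)(F)(F)F)c1` gives 12900 nM in a functional assay on CWR22R cells (Homo sapiens) for antiproliferative activity, read by propidium iodide staining, with a stated time of 96 h; on this read-out higher numbers stand for weaker inhibition and lower numbers for stronger inhibition. Compound 2 `CC(O)(CSc1cc(C(F)(F)F)cc(C(F)(F)F)c1)C(=O)Nc1cccc(S(F)(F)(F)(F)F)c1` gives 4400 nM in this assay. The change between them is trifluoromethyl in place of hydrogen on an aromatic carbon, and it produced a 2.9-fold lower number from compound 1 to compound 2 (0.47 log units; beyond the scatter).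

Compound 3 `CC(O)(COc1ccc(C#N)cc1)C(=O)Nc1cccc(S(F)(F)(F)(F)F)c1` gives 32500 nM in this assay; how its core differs from the core of compound 1 is not broken down here, and the two values are simply taken as they stand. Compound 4 `CC(O)(COc1ccc(C#N)cc1C(F)(F)F)C(=O)Nc1cccc(S(F)(F)(F)(F)F)c1` is not yet measured. It differs from compound 3 by trifluoromethyl in place of hydrogen on an aromatic carbon. This is the same kind of change as that from compound 1 to compound 2, not the same: in compound 2 the entering group sits meta to a large group and meta to a trifluoromethyl group, whereas in compound 4 it sits ortho to a large group and meta to a cyano group, so the surroundings of the place differ.

For compound 4 in this assay a step of a 2.5-fold lower number from compound 3 to compound 4 (0.40 log units; beyond the scatter) is expected, because the same kind of change gave a 2.9-fold lower number from compound 1 to compound 2 (0.47 log units; beyond the scatter) in this one measured pair, a modest gain, and the different surroundings of the place leave the size uncertain. Compound 4 is thus estimated at 13000 nM, with a range of 6000 nM to 28000 nM.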

Compound 4, half-maximal inhibitory concentration: 18300 nM
Beside the measured number, compound 4's estimate is 1.4-fold (0.15 log units) below it; low and high end bracket the measured number.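

In this assay, trifluoromethyl in place of hydrogen on an aromatic carbon gives a 1.8-fold lower number from compound 3 to compound 4 (0.25 log units; within the scatter), so on the core of compound 3 the step cannot be told from scatter, unlike the step on the core of compound 1. Set side by side, the two steps do not differ beyond what repeated measurement allows: the same change on two cores in this assay, a 2.9-fold lower number (0.47 log units; beyond the scatter) from compound 1 to compound 2 and a 1.8-fold lower number (0.25 log units; within the scatter) from compound 3 to compound 4, 1.7-fold (0.22 log units) apart, within the scatter of two such steps. This fits a change that carries from one core to the other, but it rests on two pairs only, and it shows neither that the size of the step is preserved nor whether the core or the surroundings of the place, ortho to a large group and meta to a cyano group in compound 4, govern that size.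

The compounds shown leave open how an amine or a carboxylic acid would compare with trifluoromethyl at that place. Within the data shown here, they also leave open what the sulfur and oxygen links contribute on their own, since no pair here differs only in that link.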